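Ethoxyphenyl in Place of Dimethoxypyrimidinyl: Cytotoxicity Outlook

The source may report more compounds than this note shows. Statements on the series, on what has been measured and on what is new or still open speak of the compounds shown alone.

Compound 2 `CCOC(=O)CCCCCOc1cccc(CN(C(=O)c2ccc(-c3cnc(OC)nc3OC)cc2)C(C)C)c1` was examined in an ADME assay on HEK293 cells (Homo sapiens) for cytotoxicity, read by CellTiter-Glo and resazurin assay, with a stated time of 72 h; a lower number here means that less compound is needed, a higher number that more compound is needed for the effect. For compound 2 the result is a limit of the assay and not a number, > 26000 nM. Compound 1 `CC(C)N(Cc1cccc(OCCCCCC(=O)O)c1)C(=O)c1ccc(-c2cccc(N(C)C)c2)cc1` likewise gives only a limit in this assay, > 26000 nM. For the measured compounds named here, compound 2 therefore stands at the limit of > 26000 nM in this assay, at which 2 of the 2 values shown sit, and no step between two measured compounds is available from which the effect of a change could be judged.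

Compound 3 `CCOC(=O)CCCCCOc1cccc(CN(C(=O)c2ccc(-c3cccc(OCC)c3)cc2)C(C)C)c1` differs from compound 2 in a single place: 3-ethoxyphenyl in place of 2,4-dimethoxypyrimidin-5-yl on an aromatic carbon. Because compound 2 sits at the limit of > 26000 nM in this assay, at which 2 of the 2 values shown sit, the account can only offer an expectation for this assay. The expected step is a number no higher from compound 2 to compound 3 (the limit leaves the size open), that is, none beyond the scatter. Compound 3 is accordingly expected to remain at the limit, with an estimate of 26000 nM and a range from 13000 nM to 60000 nM.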

Compound 3, half-maximal effective concentration: > 22300 nM
Compound 3 ended at the assay's limit; the forecaster's own chance of this, stated with the estimate: 80%; the middle value lies beyond the limit too.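

Compound 2 and compound 3 each give only a limit of the assay in this assay, and the step between them cannot be read. The compounds shown leave open whether 3-ethoxyphenyl in place of 2,4-dimethoxypyrimidin-5-yl changes the concentration needed for the effect at all.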